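Urea series: cytotoxicity in BJ cells, acetyl to trifluoromethyl

The source may hold more compounds than are shown below. What is called first, only, known or untested is meant among the compounds shown, and "the series" means these compounds.

Cytotoxicity in an ADME assay on BJ cells (Homo sapiens) for cytotoxicity, with a stated time of 72 h (a higher number here means that more compound is needed for the effect, a lower number that less compound is needed), is low across the three compounds measured. Compound 1 `Cc1cc(NC(=O)Nc2ncccc2C)c2ccccc2n1` reaches only the limit of the assay, > 25000 nM. Compound 2 `Cc1cc(NC(=O)Nc2cccc(Cl)c2)c2ccccc2n1` likewise stops at the limit, > 25000 nM. The step from compound 1 to compound 2, a step that the two limits leave unreadable from compound 1 to compound 2, therefore cannot be read. Within the data shown here, compound 3 `CC(=O)c1ccc(NC(=O)Nc2cc(C)nc3ccccc23)cc1` is the one compound with a number in this assay, giving 22000 nM. Compound 1 and compound 2 give only limits, so compound 3 stands alone among the numbers.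

The step to compound 4 `Cc1cc(NC(=O)Nc2ccc(C(F)(F)F)cc2)c2ccccc2n1` is trifluoromethyl in place of acetyl on an aromatic carbon. Among the measured compounds shown here, no measured step covers this exchange, and the only step available is unreadable, so no direction can be taken from the series. The picture is set by the limit of > 25000 nM in this assay, at which 2 of the 3 values shown sit, with compound 3 close to that limit as well. For compound 4 no step beyond the usual scatter is expected, and a reported limit rather than a number is likely. The estimate for compound 4 is 25000 nM, ranging from 12000 nM to 60000 nM. The expected step from compound 3 to compound 4 is a 1.1-fold higher number from compound 3 to compound 4 (0.06 log units; within the scatter).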

Compound 4, half-maximal effective concentration: > 25000 nM
Compound 4 ended at the assay's limit; the forecaster's own chance of this, stated with the estimate: 70%; the middle value lies on the limit itself.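

Among these compounds, at this aromatic carbon, para to a large group, trifluoromethyl in place of acetyl gives the first step with a readable size in this assay, whereas the step between the two earlier limits cannot be read: an at least 1.1-fold higher number from compound 3 to compound 4 (0.05 log units; that floor lies within the scatter). That size is only a floor, so the exchange shows no lower number at this position, but it sets no upper bound on the change. Compound 3 remains the only compound with a true number, and the series gathers further at a single ceiling: the limit of > 25000 nM in this assay, at which 3 of the 4 values shown sit.

From the compounds shown here alone, how far past the limit compound 4 lies remains open, and with it the true size of this exchange. Also open, going by these compounds, is whether an amine or a carboxylic acid on this aromatic carbon would give a number well inside the range of this assay.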